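A few compounds are considered here, and "the series" means these few. Any claim that something is new, unique, unknown or untested is made for them only; others in the source may bear on it.

Compound 1 `CCOc1cc(=O)n(CCCO)c2c1CC(CC=C(C)C)C(C)(C)C2`: 16.6%
Compound 2 `CC(C)=CCC1Cc2c(OCc3ccccc3)cc(=O)n(CCCO)c2CC1(C)C`: 11.1%

In a functional assay on PANC-1 cells (Homo sapiens) for inhibition, read by MTT assay, with a stated time of 24 h, tested at 10 uM (a higher number here means more inhibition at the concentration tested (going by the name of the read-out), a lower number less inhibition), compound 1 gives 16.6%, and compound 2 gives 11.1%. These two numbers stand within the scatter of each other, the step being a number 5.5 percentage points lower from compound 1 to compound 2 (within the scatter). Compound 3 `CC(C)=CCC/C(C)=C/COc1cc(=O)n(CCCO)c2c1CC(CC=C(C)C)C(C)(C)C2` differs from compound 1 as follows: 2,6-dimethylhepta-1,5-dien-1-yl in place of methyl on a saturated chain carbon bound to an oxygen on an aromatic ring. Going by the values given here, the one step that bears on this, a change at the same place, stayed within the scatter, so I expect no step beyond the scatter here either: a number 0.4 percentage points higher from compound 1 to compound 3 (within the scatter). My estimate for compound 3 is 17%, expected to fall between 5% and 35%.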

Compound 3, a percentage reported as inhibition, at one concentration (the size of the read-out at that concentration, not a potency): 18.4%
Beside the measured number, compound 3's estimate is 1.4 percentage points below it; the range from low to high includes it.
By their numbers in this assay, from the lowest: compounds 2, 1 and 3 (each within the scatter of the next).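

Replacing the methyl with the far larger 2,6-dimethylhepta-1,5-dien-1-yl at this place, on a saturated chain carbon bound to an oxygen on an aromatic ring, leaves this assay within the scatter (a number 1.8 percentage points higher from compound 1 to compound 3 (within the scatter)), and the same holds against phenyl (a number 7.3 percentage points higher from compound 2 to compound 3 (within the scatter)). Methyl, phenyl and this long unsaturated chain thus give numbers within the scatter of one another. No measurement shown here offers an explanation for this. Going by these compounds, whether an amine or a carboxylic acid at this place would give a step beyond the scatter remains open.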